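Widening the Fused Ring: From Compound 2 to Compound 3

A few compounds are considered here, and "the series" means these few. Any claim that something is new, unique, unknown or untested is made for them only; others in the source may bear on it.

Measured so far:
compound 1: `CCC(C)n1ccnc1-c1cccc(Cl)c1CCc1cc(Br)ccc1OC` — 2100 nM
compound 2: `COc1ccc(Br)cc1CCc1c(Cl)cccc1-c1ncc2n1CCC2` — 710 nM

Of the compounds shown here, two have been measured in a functional assay on HEK293 cells (Homo sapiens), read by cAMP accumulation; on this read-out lower numbers stand for stronger inhibition and higher numbers for weaker inhibition. Compound 1 `CCC(C)n1ccnc1-c1cccc(Cl)c1CCc1cc(Br)ccc1OC` gives 2100 nM, and compound 2 `COc1ccc(Br)cc1CCc1c(Cl)cccc1-c1ncc2n1CCC2` gives 710 nM. Compound 2 thus stands at the lower of the two numbers, separated from compound 1 by the step of a 3.0-fold lower number from compound 1 to compound 2 (0.47 log units; beyond the scatter). Compound 3 `COc1ccc(Br)cc1CCc1c(Cl)cccc1-c1ncc2n1CCCC2` differs from compound 2 in one place: a group of 9 heavy atoms (7 carbon, 2 nitrogen; one five-membered aromatic ring with 2 hetero atoms, one six-membered non-aromatic ring with 1 hetero atom) in place of a group of 8 heavy atoms (6 carbon, 2 nitrogen; one five-membered non-aromatic ring with 1 hetero atom, one five-membered aromatic ring with 2 hetero atoms), on an aromatic carbon. Among the measured compounds shown here, only one measured step exists, and it concerns a different change at the same position, so it bears on the present step only loosely; it shows that altering this group can move the number by a modest amount. Replacing the five-membered non-aromatic ring with a six-membered one is expected to leave the number close to that of compound 2, within the scatter or a small change in either direction. Compound 3 is therefore expected to give 600 nM, with a range from 200 nM to 1800 nM. This estimate corresponds to an expected step of a 1.2-fold lower number from compound 2 to compound 3 (0.07 log units; within the scatter).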

Compound 3, half-maximal inhibitory concentration: 590 nM
Estimate against measurement, compound 3: 1.0-fold (0.01 log units) above; the measured number falls inside the stated range.
By their numbers in this assay, from the lowest: compounds 3 and 2 (each within the scatter of the next); then compound 1.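

In this assay, going from the five-membered to the six-membered non-aromatic fused ring on this aromatic carbon gives a 1.2-fold lower number from compound 2 to compound 3 (0.08 log units; within the scatter), so this ring size can vary without a change beyond the scatter, which the earlier pair could not show. Compared with the group of compound 1, which carries a single five-membered aromatic ring, the six-membered fused group gives a 3.6-fold lower number from compound 1 to compound 3 (0.55 log units; beyond the scatter), so the step seen earlier for the five-membered fused ring, a 3.0-fold lower number from compound 1 to compound 2 (0.47 log units; beyond the scatter), is not confined to that one ring size. No supporting data are available to explain these results.

Going by these compounds, it remains open whether a seven-membered fused ring would fit this pattern, or how an amine or a hydroxyl group on the non-aromatic ring would act. The compounds shown also leave open how replacing the chloro group on the shared core would affect the number.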